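The source may report more compounds than this note shows. Statements on the series, on what has been measured and on what is new or still open speak of the compounds shown alone.

Measured compounds:
compound 1 `COc1cc2c(Oc3ccc(NC(=O)c4nn(-c5ccccc5)c(=O)c5ccccc45)cc3F)ccnc2cc1OCCCN1CCCC1` — in a functional assay on HT-29 cells (Homo sapiens) for cytotoxicity, read by MTT assay, with a stated time of 72 h (a higher number here means a weaker inhibitor, a lower number a stronger inhibitor), compound 1 gives 980 nM
compound 2 `COc1cc2c(Oc3ccc(NC(=O)c4nn(-c5ccccc5)c(=O)c5ccccc45)cc3F)ccnc2cc1OCCCN1CCN(C)CC1` — compound 2 gives 1140 nM

Of the two numbers shown, compound 2 stands alongside compound 1, the step of a 1.2-fold higher number from compound 1 to compound 2 (0.07 log units; within the scatter) lying within the scatter, so the two cannot be told apart. Compound 3 `COc1cc2c(Oc3ccc(NC(=O)c4nn(-c5ccc([N+](=O)[O-])cc5)c(=O)c5ccccc45)cc3F)ccnc2cc1OCCCN1CCN(C)CC1` differs from compound 2 by nitro in place of hydrogen on an aromatic carbon. Among the measured compounds shown here, the only measured step, a 1.2-fold higher number from compound 1 to compound 2 (0.07 log units; within the scatter), concerns the saturated chain, not the phenyl, and so does not bear on this change. For the measured compounds named here, with no step to guide it, nothing beyond the scatter is expected in this assay. Compound 3 is therefore estimated at about 1100 nM, with a range of 350 nM to 3500 nM. This estimate means an expected step of a 1.0-fold lower number from compound 2 to compound 3 (0.02 log units; within the scatter).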

Compound 3, half-maximal inhibitory concentration: 2560 nM
The estimate for compound 3 lay 2.3-fold (0.37 log units) below the measured number; low and high end bracket the measured number.
By their numbers in this assay, from the lowest: compounds 1 and 2 (each within the scatter of the next); then compound 3.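

In this assay the phenyl ring proves sensitive to substitution: nitro in place of hydrogen, para to a large group, gives a 2.2-fold higher number from compound 2 to compound 3 (0.35 log units; beyond the scatter) and so a step beyond the scatter, unlike the earlier change on the saturated chain. Here, then, the added nitro goes with a weaker inhibitor. Nothing measured here explains this step.

Going by these compounds, whether a chlorine or an amine at the same carbon would shift the number likewise stays open. So does whether nitro would give a similar step with the pyrrolidin-1-yl chain of compound 1.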